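The compounds below may be only part of what the source reports. "The series", "measured", "known", "first", "only" and "open" are said of these compounds alone.

Two measured compounds share one core. Compound 1, `CC(C)C(c1ccc(-c2ccc3cccc(F)c3c2)[nH]c1=O)N1CCCCC1=O`, carries 2-oxopiperidin-1-yl on a saturated chain carbon bound to an aromatic carbon and a saturated chain carbon, and in an assay on CHO cells for displacement of a labelled ligand from prostaglandin E2 receptor EP3 subtype (Homo sapiens), read by radioligand binding (a lower number here means a stronger inhibitor, a higher number a weaker inhibitor), compound 1 gives 6.4 nM. Compound 2, `CC(C)C(c1nnc[nH]1)c1ccc(-c2ccc3cccc(F)c3c2)[nH]c1=O`, carries 4H-1,2,4-triazol-3-yl at that place, and in this assay compound 2 gives 12 nM. For the measured compounds named here, the single step between them, a 1.9-fold higher number from compound 1 to compound 2 (0.27 log units; within the scatter), stays within the scatter. Going by the values given here, compound 2 thus has the higher of the two numbers, but its only neighbour, compound 1, sits within the scatter of it, so no order can be read.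

Compound 3, `CC(C)C(c1cnc(N)s1)c1ccc(-c2ccc3cccc(F)c3c2)[nH]c1=O`, differs from compound 2 by 2-amino-1,3-thiazol-5-yl in place of 4H-1,2,4-triazol-3-yl on a saturated chain carbon bound to an aromatic carbon and a saturated chain carbon. Among the compounds with values here, the only step bearing on an exchange at this place is a 1.9-fold higher number from compound 1 to compound 2 (0.27 log units; within the scatter), and it was within the scatter. Since the entering group is again a five-membered aromatic ring with one hydrogen-bond donor, the step of no change at the digits printed from compound 2 to compound 3 (within the scatter) is expected to stay within the scatter. Compound 3 is therefore estimated at 12 nM in this assay, with a range from 4 nM to 36 nM.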

Compound 3, inhibition constant: 16 nM
The estimate for compound 3 lay 1.3-fold (0.12 log units) below the measured number; the range from low to high includes it.
By their numbers in this assay, from the lowest: compounds 1, 2 and 3 (each within the scatter of the next, the first and the last beyond it).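

In this assay the exchange gives a 1.3-fold higher number from compound 2 to compound 3 (0.12 log units; within the scatter) and so shows that this place, on a saturated chain carbon bound to an aromatic carbon and a saturated chain carbon, takes a second five-membered aromatic ring, now carrying sulfur and an amino group, with no change that can be told from the scatter. For the compounds shown here, the comparison with the lactam gives a 2.5-fold higher number from compound 1 to compound 3 (0.40 log units; beyond the scatter) and is the first step at this place to pass beyond the scatter, though it is modest, so 2-oxopiperidin-1-yl and 2-amino-1,3-thiazol-5-yl can be put in order, while 4H-1,2,4-triazol-3-yl cannot be separated from either. No measurement offered here explains these differences.

As far as these compounds go, it remains open how a carboxylic acid or an open-chain amine at this place would compare. Also open, from the compounds shown here alone, is what a plain 1,3-thiazol-5-yl ring, without the amino group, would give.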